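The compounds below may be only part of what the source reports. "The series", "measured", "known", "first", "only" and "open" are said of these compounds alone.

Of the compounds shown here, three carrying the shared core have been measured in a physicochemical assay for lipophilicity, read by HPLC, measured as chromatographic lipophilicity, at pH 7.4; a lower number here means a more polar compound, a higher number a more lipophilic compound. Compound 1 `O=C(c1cscn1)N1CCC(C(=O)N2N=CC[C@H]2c2ccccc2)CC1` gives 3 in this assay. Compound 2 `Cc1nnc(N2CCC(C(=O)N3N=CC[C@H]3c3cc(F)cc(F)c3)CC2)o1`, which has a difluorophenyl in place of the phenyl and a methyl-oxadiazolyl set directly on the amine nitrogen in the ring, gives 3.6, a value beyond the scatter above that of compound 1. Compound 3 `CN1CCC(C(=O)N2N=CCC2c2ccccc2)CC1`, with a methyl on that ring nitrogen, gives 1.1, far below compound 1 and well beyond the scatter. Compound 1 thus stands second highest of the three, nearest to compound 2 and furthest from compound 3.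

Compound 4 `O=C(C1CCN(c2ccccn2)CC1)N1N=CC[C@H]1c1ccccc1` has not yet been measured in this assay. It differs from compound 1 in one place: pyridin-2-yl in place of (1,3-thiazol-4-yl)carbonyl on an amine nitrogen in a ring. The carbonyl and the sulfur-containing five-membered aromatic ring leave, and a six-membered aromatic ring with one nitrogen enters directly on the amine nitrogen in the ring.

Because compound 2, which also carries an aromatic ring directly on that nitrogen, gives 3.6, the step from compound 1 to compound 4 is expected to go upward, beyond the scatter, by about a number 0.70 log units higher from compound 1 to compound 4 (beyond the scatter). Compound 4 is therefore estimated at 3.7, with a range from 3.1 to 4.3.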

Compound 4, distribution coefficient: 5.1
Beside the measured number, compound 4's estimate is 1.40 log units below it, and the stated range ends below it.
By their numbers in this assay, from the lowest: compound 3; then compound 1; then compound 2; then compound 4.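

In this assay, the amine nitrogen in the ring proves to be a place where a single exchange can move the reading a long way: pyridin-2-yl in place of (1,3-thiazol-4-yl)carbonyl gives a number 2.10 log units higher from compound 1 to compound 4 (beyond the scatter). Among the compounds shown here, the earlier compounds could not show this, since no two of them differ in only one place, so this is the first step whose size belongs to one change alone. That change is also more than a swap of one aromatic ring for another: the carbonyl leaves, the five-membered ring with its sulfur leaves, and a six-membered aromatic ring with one nitrogen sits directly on the amine nitrogen. Nothing measured here explains why the number moves so far.

This one step does not separate the loss of the carbonyl from the change of ring. A pyridinylcarbonyl group, which would keep the carbonyl, or a thiazolyl set directly on the amine nitrogen, would pull those two parts apart, while a plain phenyl there would show what the ring nitrogen of the pyridine contributes.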